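Changing the amide substituent on the shared core

The source may hold more compounds than are shown below. What is called first, only, known or untested is meant among the compounds shown, and "the series" means these compounds.

Compound 1 `COc1cc([C@H]2C[C@]2(CO)C(=O)Nc2ccccc2Cl)cc(OC)c1OC` in a functional assay on HeLa cells (Homo sapiens) for cytotoxicity, read by MTT assay, with a stated time of 48 h (a higher number here means a weaker inhibitor, a lower number a stronger inhibitor), gives 45500 nM. Compound 3 `CCOC(=O)[C@@]1(C(=O)Nc2ccccc2Cl)C[C@H]1c1cc(OC)c(OC)c(OC)c1` gives 14400 nM in this assay. Compound 2 `CCOC(=O)[C@]1(C(=O)Nc2ccccc2Cl)C[C@@H]1c1cc(OC)c(OC)c(OC)c1` reaches only a limit in this assay, reported as > 100000 nM, so it sits at the weak end of the numbers shown, with no exact figure known (the limit of > 100000 nM in this assay, at which 1 of the 3 values shown sits). Two measured steps exist: an at least 2.1-fold higher number from compound 1 to compound 2 (0.34 log units; beyond the scatter), and an at least 6.9-fold lower number from compound 2 to compound 3 (0.84 log units; beyond the scatter), the latter resting on (the fact that compounds 2 and 3 differ only in the configuration as drawn). Compound 4 `CCOC(=O)[C@]1(C(=O)NCc2ccc(C)cc2)C[C@@H]1c1cc(OC)c(OC)c(OC)c1` differs from compound 2 by 4-methylbenzyl in place of 2-chlorophenyl on an amide-type nitrogen. Neither measured step touches the amide-type nitrogen; one changes the group on a saturated ring carbon and the other only the configuration, so neither bears on this change, and no direction or size of step in this assay can be read from them. Compound 4 is therefore expected to remain close to the limit where compound 2 stands, an estimated step of a number no higher from compound 2 to compound 4 (the limit leaves the size open). For compound 4 the expected value is 100000 nM, within a range from 30000 nM to 300000 nM.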

Compound 4, half-maximal inhibitory concentration: > 100000 nM
Compound 4 gave a limit, no number; the forecaster's own chance of this, stated with the estimate: 60%; the middle value sits exactly at the limit.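

Within the data shown here, compound 2 and compound 4 both end at a limit in this assay, so no step between them can be read: the limit of > 100000 nM in this assay, at which 2 of the 4 values shown sit. The compounds shown leave open whether 4-methylbenzyl in place of 2-chlorophenyl on an amide-type nitrogen shifts the number in this assay at all.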